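A few compounds are considered here, and "the series" means these few. Any claim that something is new, unique, unknown or untested is made for them only; others in the source may bear on it.

Compound 1 `COc1cc(C2=C(c3cc(C)c(OC)c(C)c3)C(O)CC2=O)cc(OC)c1OC` and compound 2 `COc1cc(C2=C(c3cc(C)c(OC)c(C)c3)C(OC(C)=O)CC2=O)cc(OC)c1OC` share one core, while compound 3 `COc1ccc(C2=C(c3cc(OC)c(OC)c(OC)c3)C(=O)C(O)C2)cc1Cl` and compound 4 `COc1ccc(C2=C(c3cc(OC)c(OC)c(OC)c3)C(=O)C(OC(C)=O)C2)cc1Cl` share another; the difference between the two cores is not broken down here. In an ADME assay on HT-29 cells (Homo sapiens) for cytotoxicity, read by MTT assay, with a stated time of 72 h (on this read-out lower numbers stand for stronger inhibition and higher numbers for weaker inhibition), compound 1 gives > 100 ug/mL, which is a limit of the assay. Compound 2 gives > 100 ug/mL in this assay, again a limit. The change from compound 1 to compound 2, (acetyl in place of hydrogen on an oxygen on a saturated carbon), therefore gives a step of unreadable size, a step that the two limits leave unreadable from compound 1 to compound 2, because of the limit of > 100 ug/mL in this assay, at which 2 of the 3 values shown sit. Compound 3 gives < 1 ug/mL in this assay, a limit as well, as noted in the limit of < 1 ug/mL in this assay, at which 1 of the 3 values shown sits. Compound 4 carries the same change as compound 2, (acetyl in place of hydrogen on an oxygen on a saturated carbon). Since the earlier step is unreadable, compound 4 is expected to stay near compound 3, with an estimated step that the limit leaves unreadable from compound 3 to compound 4. Compound 4 is estimated at 0.8 ug/mL, between 0.2 ug/mL and 4 ug/mL.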

Compound 4, half-maximal inhibitory concentration: < 1 ug/mL
Compound 4: only a limit was reported; the forecaster's own chance of this, stated with the estimate: 55%; the middle value lies beyond the limit too.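

Compound 3 and compound 4 both sit at a limit, so no step can be read from compound 3 to compound 4: the limit of < 1 ug/mL in this assay, at which 2 of the 4 values shown sit. The compounds shown leave open whether acetyl in place of hydrogen changes the result in this assay on either core.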